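The source may report more compounds than this note shows. Statements on the series, on what has been measured and on what is new or still open speak of the compounds shown alone.

Measured so far:
- compound 1 `O=C1C(Nc2ccccc2)=CC(=O)c2c1nc1n2[C@H]2OC[C@@H](O)[C@H]2OC1`: > 4000 nM
- compound 2 `O=C1C=C(Nc2cccc(F)c2)C(=O)c2c1nc1n2[C@H]2OC[C@@H](O)[C@H]2OC1`: 5500 nM

Both compounds were tested in a functional assay on MCF7 cells (Homo sapiens) for inhibition, read by sulforhodamine B assay; on this read-out higher numbers stand for weaker inhibition and lower numbers for stronger inhibition. Compound 1 gives > 4000 nM, which is a limit of the assay rather than a number. For the measured compounds named here, compound 2, at 5500 nM, is the only compound with a full number. The value of compound 1 is a limit (the limit of > 4000 nM in this assay, at which 1 of the 2 values shown sits). Going by the values given here, no two measured compounds differ in a single place, so no measured step is available to guide a prediction.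

Compound 3 `O=C1C=C(Nc2cccc(Cl)c2)C(=O)c2c1nc1n2[C@H]2OC[C@@H](O)[C@H]2OC1` is not yet measured. It differs from compound 2 by chloro in place of fluoro on an aromatic carbon. Among the compounds with values here, with no measured step to lean on, the expectation for compound 3 in this assay is a shift no larger than the usual scatter, and no particular direction can be claimed. The estimate for compound 3 is 4000 nM, with a range from 1500 nM to 12000 nM. This estimate means a step of a 1.4-fold lower number from compound 2 to compound 3 (0.14 log units; within the scatter), expected to stay within the scatter of repeated measurements.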

Compound 3, half-maximal inhibitory concentration: 4720 nM
Beside the measured number, compound 3's estimate is 1.2-fold (0.07 log units) below it; measured number inside the range.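

In this assay, putting chloro in place of fluoro on the aromatic carbon, meta to a large group, gives a 1.2-fold lower number from compound 2 to compound 3 (0.07 log units; within the scatter). For the compounds shown here, this is the first single-place comparison, and it shows that these two halogens cannot be told apart at this position on this read-out, since the step is no larger than the differences expected between repeated measurements. No measured property of either group bears on this step, so the data offer no explanation for it.

Fluoro and chloro each add a single heavy atom with no hydrogen-bond donors or acceptors, so the step says nothing about how a quite different group at this position, such as an amine, a carboxylic acid or a longer chain, would behave. On these data alone, compound 1 gives > 4000 nM, which is a limit of the assay and not a number, and it differs from compound 2 in more than one place, so what happens with no halogen on this ring remains open.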